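A few compounds are considered here, and "the series" means these few. Any claim that something is new, unique, unknown or untested is made for them only; others in the source may bear on it.

Three compounds have numbers in a functional assay on L1210 cells (Mus musculus) for antiproliferative activity; a higher number here means a weaker inhibitor, a lower number a stronger inhibitor:
compound 1 `O=c1[nH]c(=O)n([C@H]2C[C@H](O)[C@@H](COP(=O)(O)O)O2)cc1Br` gives 457 ug/mL;
compound 2 `O=c1[nH]c(=O)n([C@H]2C[C@@H]3O[PH](O)(O)OC[C@H]3O2)cc1F` gives 7.4 ug/mL;
compound 3 `O=c1[nH]c(=O)n([C@H]2C[C@H](O)[C@@H](COP(=O)(O)O)O2)cc1C(F)(F)F` gives 38 ug/mL.

Compound 2 has the lowest number of the three; compound 3 stands nearest and compound 1 furthest, both beyond the scatter. Compound 4 `O=c1[nH]c(=O)n([C@H]2C[C@@H]3O[PH](O)(O)OC[C@H]3O2)cc1I` differs from compound 2 in one place: iodo in place of fluoro on an aromatic carbon. Among the measured compounds shown here, no measured step swaps fluoro for iodo. For the measured compounds named here, the only step at this aromatic carbon is a 12-fold lower number from compound 1 to compound 3 (1.08 log units; beyond the scatter), taken on the open phosphate, and it shows that the group at this place can move the number a long way. With iodo in place of fluoro the number is expected to rise. The estimate for compound 4 is 50 ug/mL, between 10 ug/mL and 300 ug/mL. This expected change, a 6.8-fold higher number from compound 2 to compound 4 (0.83 log units; beyond the scatter), would lie beyond the scatter.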

Compound 4, concentration for 50% inhibition: > 500 ug/mL
Compound 4 gave a limit, no number; the forecaster's own chance of this, stated with the estimate: 5%; middle value at least 10-fold (1.00 log units) away from the limit.
By their numbers in this assay, from the lowest: compound 2; then compound 3; then compound 1. At a limit, above all of these: compound 4.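

In this assay, iodo in place of fluoro on this aromatic carbon brings a large weakening on the core of compound 2: an at least 67-fold higher number from compound 2 to compound 4 (1.82 log units; beyond the scatter). The earlier step at this carbon, a 12-fold lower number from compound 1 to compound 3 (1.08 log units; beyond the scatter), stood on a different core and involved neither fluoro nor iodo. Compound 4 gives only a limit, not a number: the limit of > 500 ug/mL in this assay, at which 1 of the 4 values shown sits.

As far as these compounds go, how bromo or trifluoromethyl would behave on the core of compound 2 stays open. So does the effect of an amine or a longer chain such as ethyl at this aromatic carbon.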